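The source may report more compounds than this note shows. Statements on the series, on what has been measured and on what is new or still open speak of the compounds shown alone.

Compound 1 `O=C(OCCCCCCCCO)OCCc1ccc(O)c(O)c1`: > 50000 nM
Compound 2 `CCCCCCOC(=O)OCCc1ccc(OCc2ccccc2)c(OCc2ccccc2)c1`: "not determined" (no result reported)

In an ADME assay on MRC5 cells (Homo sapiens) for inhibition, read by MTT assay, with a stated time of 72 h (on this read-out higher numbers stand for weaker inhibition and lower numbers for stronger inhibition), compound 1 gives > 50000 nM. This is a limit of the assay and not a number, so compound 1 has no exact position (the limit of > 50000 nM in this assay, at which 1 of the 2 values shown sits). For the measured compounds named here, compound 2 has no result, and no measured step offers a guide. Compound 3 `CCCCCCCCCOC(=O)OCCc1ccc(O)c(O)c1` differs from compound 1 by methyl in place of hydroxy on a saturated chain carbon, eight bonds along the chain from an oxygen next to a carbonyl group. In this assay, a small move toward stronger inhibition is expected, giving an estimated at least 1.2-fold lower number from compound 1 to compound 3 (0.09 log units; that floor lies within the scatter). For compound 3, the expected value is 40000 nM, within an estimated range of 15000 nM to 60000 nM.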

Compound 3, half-maximal inhibitory concentration: 15900 nM
Compound 3: the middle estimate sits 2.5-fold (0.40 log units) above what was measured; the measured number falls inside the stated range.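

Methyl in place of hydroxy on this saturated chain carbon gives an at least 3.1-fold lower number from compound 1 to compound 3 (0.49 log units; beyond the scatter) in this assay, so this position does affect the read-out. As far as these compounds go, the value of compound 1 is a limit of the assay and not a number, so the true size of the step stays unknown: the limit of > 50000 nM in this assay, at which 1 of the 3 values shown sits.

The compounds shown leave open whether a longer chain, a shorter chain, or an amine or a carboxylic acid at this carbon would move the number further. They also leave open whether the step holds on any other core.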